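This account rests on a few compounds, and the source may have more. Where it says the series, first, only, none or still open, it means among the compounds named here.

Among the measured compounds shown here, compound 3 `COc1ccccc1NC(=O)Nc1nn(-c2ccccc2)c(=O)c2ccccc12` stands second of the three compounds measured so far in an assay on CHO cells for displacement of a labelled ligand from adenosine receptor A3 (Homo sapiens); on this read-out higher numbers stand for weaker inhibition and lower numbers for stronger inhibition. In this assay compound 3 gives 8.9 nM. Compound 2 `COc1ccc(OC)c(NC(=O)Nc2nn(-c3ccccc3)c(=O)c3ccccc23)c1` gives 0.776 nM, and compound 1 `O=C(Nc1nn(-c2ccccc2)c(=O)c2ccccc12)c1ccccc1` gives 1100 nM; the measured steps are an 11-fold higher number from compound 2 to compound 3 (1.06 log units; beyond the scatter) and a 120-fold lower number from compound 1 to compound 3 (2.09 log units; beyond the scatter). Compound 4 `O=C(Nc1ccccc1)Nc1nn(-c2ccccc2)c(=O)c2ccccc12` has not yet been measured. The change from compound 3 to compound 4 is hydrogen in place of methoxy on an aromatic carbon. For the measured compounds named here, one measured step bears directly on this: the move from compound 2 to compound 3 also took away a methoxy group, and that step read an 11-fold higher number from compound 2 to compound 3 (1.06 log units; beyond the scatter). Going by the values given here, since the earlier loss weakened binding clearly, the loss of the remaining methoxy group is expected to raise the number again, though the single earlier step leaves the size uncertain. The expected step is a 6.7-fold higher number from compound 3 to compound 4 (0.83 log units; beyond the scatter). Compound 4 is therefore estimated at 60 nM, with a range from 12 nM to 300 nM.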

Compound 4, inhibition constant: 178 nM
The estimate for compound 4 lay 3.0-fold (0.47 log units) below the measured number; the range from low to high includes it.
By their numbers in this assay, from the lowest: compound 2; then compound 3; then compound 4; then compound 1.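

Taking away the methoxy group ortho to a large group, which turns 2-methoxyphenyl into phenyl, clearly weakens inhibition in this assay on its own (a 20-fold higher number from compound 3 to compound 4 (1.30 log units; beyond the scatter)), so this group matters even with no second methoxy group on the ring. Going from 2,5-dimethoxyphenyl to plain phenyl gives the full loss across the pair (a 230-fold higher number from compound 2 to compound 4 (2.36 log units; beyond the scatter)). Anilino in place of phenyl on the carbonyl carbon still lowers the number with no methoxy group present (a 6.2-fold lower number from compound 1 to compound 4 (0.79 log units; beyond the scatter)), so part of the gain over compound 1 needs no methoxy group, while the methoxy groups add much more.

Nothing shown explains why these steps are so large. From the compounds shown here alone, whether a hydroxyl group, a chlorine atom or an ethoxy group on that same carbon would hold the number down as methoxy does remains open.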